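The compounds below may be only part of what the source reports. "The series", "measured", "known", "first", "only" and "open" are said of these compounds alone.

Measured so far:
Compound 1 `Cc1nc(NCc2cccc(C(=O)O)c2)c2cn[nH]c2n1`: in an assay for inhibition of Indoleamine 2,3-dioxygenase 1 (Homo sapiens), read by spectrophotometry, with a stated time of 180 min, tested at 10 uM (a lower number here means a weaker effect, a higher number a stronger effect of the compound at the concentration tested), compound 1 gives 5%.
Compound 2 `Cc1nc(NCc2ccc(C(=O)O)cc2)c2cn[nH]c2n1`: in this assay compound 2 gives 5%.
Compound 3 `O=C(O)c1cccc(CNc2ncnc3[nH]ncc23)c1`: in this assay compound 3 gives 2%.

All three of these numbers lie within the scatter of one another, so none of the three can be set apart. Compound 3 is compound 1 after one change, (hydrogen in place of methyl on an aromatic carbon), and that change made a number 3 percentage points lower from compound 1 to compound 3 (within the scatter). Compound 4 `O=C(O)c1ccc(CNc2ncnc3[nH]ncc23)cc1` is not yet measured in this assay; it is compound 2 after the same change at the same place, (hydrogen in place of methyl on an aromatic carbon). Compound 1 and compound 2 share the same atoms joined differently, and the difference between the two cores is not broken down here. Because the earlier instance gave a number 3 percentage points lower from compound 1 to compound 3 (within the scatter), the step from compound 2 to compound 4 is expected to be a number 2 percentage points lower from compound 2 to compound 4 (within the scatter). Compound 4 is therefore estimated at 3%, with a likely range from -5% to 12%.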

Compound 4, a percentage reported as inhibition, at one concentration (the size of the read-out at that concentration, not a potency): 3%
Beside the measured number, compound 4's estimate shows no gap at the digits printed; the measured number falls inside the stated range.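

Replacing methyl with hydrogen on the aromatic carbon between two ring nitrogen atoms gives, in this assay, a number 2 percentage points lower from compound 2 to compound 4 (within the scatter). Set beside the earlier step, the change behaves alike on the two cores: the same change on two cores in this assay, a number 3 percentage points lower (within the scatter) from compound 1 to compound 3 and a number 2 percentage points lower (within the scatter) from compound 2 to compound 4, 1 percentage points apart, within the scatter of two such steps. This shows that the change carries over without a visible difference, but neither step can be told from scatter, and all four compounds show little inhibition, so it does not show that the change has a real effect or how it would behave in a more active compound.

The compounds shown leave open what an amine or a longer chain would do on that same carbon. They also leave open what an amide would do in place of the carboxylic acid.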